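Tetrazole in place of methylsulfonyl in the series

The source may hold more compounds than are shown below. What is called first, only, known or untested is meant among the compounds shown, and "the series" means these compounds.

Three compounds of the series have numbers in a functional assay on isolated protein for agonist activity at Glucose-dependent insulinotropic receptor (Mus musculus), read by cAMP accumulation; on this read-out higher numbers stand for an effect only at larger amounts of compound and lower numbers for an effect already at smaller amounts. Compound 1 `O=S(=O)(CCO)c1ccc(COC[C@@H]2C[C@@H]2C2CCN(c3ncc(Cl)cn3)CC2)c(F)c1` gives 1.7 nM, compound 2 `CCc1cnc(N2CCC([C@H]3C[C@H]3COCc3ccc(S(C)(=O)=O)cn3)CC2)nc1` gives 2.5 nM, and compound 3 `CC(C)c1noc(N2CCC([C@H]3C[C@H]3COCc3ccc(S(C)(=O)=O)cc3F)CC2)n1` gives 9.9 nM. Compound 3 thus stands with the highest of the three numbers; its gaps to compound 2 and to compound 1 are both beyond the usual scatter, whereas compounds 1 and 2 lie within the scatter of each other.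

The next step keeps the core of compound 3 and alters one group: 1H-tetrazol-1-yl in place of methylsulfonyl on an aromatic carbon. The result is compound 4 `CC(C)c1noc(N2CCC([C@H]3C[C@H]3COCc3ccc(-n4cnnn4)cc3F)CC2)n1`. For the measured compounds named here, no two measured compounds differ in this one place, so there is no measured step of this kind to lean on, and the direction of the change in this assay is open. A step of modest size is expected, more likely toward a higher number than a lower one, with a step within the scatter also possible. The expected step from compound 3 to compound 4 is a 1.5-fold higher number from compound 3 to compound 4 (0.18 log units; within the scatter). For compound 4 the estimate in this assay is 15 nM, with a range from 5 nM to 50 nM.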

Compound 4, half-maximal effective concentration: 4.8 nM
Beside the measured number, compound 4's estimate is 3.1-fold (0.49 log units) above it, outside the stated range (below it).
By their numbers in this assay, from the lowest: compounds 1, 2 and 4 (each within the scatter of the next, the first and the last beyond it); then compound 3.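

In this assay, 1H-tetrazol-1-yl in place of methylsulfonyl gives a 2.1-fold lower number from compound 3 to compound 4 (0.31 log units; beyond the scatter), a modest step, on the aromatic carbon meta to a fluoro group and para to a large group. For the compounds shown here, all the earlier compounds carry a sulfonyl group on their aromatic ring, whereas compound 4 shows that, on the core of compound 3, this position also accepts a five-membered aromatic ring with 4 hetero atoms and no sulfur, without a higher number. Nothing on hand bears on what lies behind this step.

From the compounds shown here alone, this is a single step on a single core, so whether it carries over to the cores of compound 1 and compound 2 remains open. Also open, going by these compounds, is how a nitrile, a carboxylic acid or a primary amide on the same aromatic carbon would read in this assay.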